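Replacing piperidin-4-yl in compound 3

A few compounds are considered here, and "the series" means these few. Any claim that something is new, unique, unknown or untested is made for them only; others in the source may bear on it.

In an ADME assay on BaF3 cells (Mus musculus) for cytotoxicity (a lower number here means that less compound is needed, a higher number that more compound is needed for the effect), compound 3 (`O=C(Nc1cccc(C(F)(F)F)c1)c1cccc(-c2ccc3nc(NC(=O)C4CCNCC4)sc3n2)c1`) reads > 10000 nM, which is a limit of the assay and not a number. Compound 1 (`CC(=O)Nc1nc2ccc(-c3cccc(C(=O)Nc4cccc(C(F)(F)F)c4)c3)nc2s1`), with methyl on the same carbonyl carbon, also gives only a limit, > 10000 nM. Compound 2 (`O=C(Nc1cccc(C(F)(F)F)c1)c1cccc(-c2ccc3nc(NC(=O)C4CC4)sc3n2)c1`), with cyclopropyl there, gives a true number, 910 nM. Among the compounds with values here, the series so far is therefore dominated by the limit of > 10000 nM in this assay, at which 2 of the 3 values shown sit.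

Compound 4 (`CC(=O)N1CCN(CCC(=O)Nc2nc3ccc(-c4cccc(C(=O)Nc5cccc(C(F)(F)F)c5)c4)nc3s2)CC1`) carries 2-(4-acetylpiperazin-1-yl)ethyl in place of piperidin-4-yl on a carbonyl carbon, the difference being (2-(4-acetylpiperazin-1-yl)ethyl in place of piperidin-4-yl on a carbonyl carbon). Within the data shown here, three measured steps bear on this change, all at the same place. Two of them are large and run in opposite directions: an at least 10-fold lower number from compound 1 to compound 2 (1.04 log units; beyond the scatter), and an at least 10-fold higher number from compound 2 to compound 3 (1.04 log units; beyond the scatter). The third is a step that the two limits leave unreadable from compound 1 to compound 3.

This place can clearly move the number, but only compound 2 has left the limit, so the direction for a new group is poorly fixed. The expected step is an at least 1.6-fold lower number from compound 3 to compound 4 (0.22 log units; that floor lies within the scatter), an estimate that leans towards a lower number, with a real chance that only a limit is reported again. For compound 4 the estimated value is 6000 nM, with an expected range from 1000 nM to 20000 nM.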

Compound 4, half-maximal effective concentration: > 10000 nM
Compound 4 was reported as a limit; the forecaster's own chance of this, stated with the estimate: 50%; at least 1.6-fold (0.22 log units) between middle value and limit.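

Compound 2, with cyclopropyl, remains the only compound here to leave the limit in this assay, and compound 4 adds a further group at that limit: the limit of > 10000 nM in this assay, at which 3 of the 4 values shown sit.

Within the data shown here, the one readable new step is an at least 10-fold higher number from compound 2 to compound 4 (1.04 log units; beyond the scatter). Replacing piperidin-4-yl, with 1 hydrogen-bond donor and 6 heavy atoms, by 2-(4-acetylpiperazin-1-yl)ethyl, with 0 hydrogen-bond donors and 11 heavy atoms, therefore still gives no true number on this carbonyl carbon, and the steps from compound 3 and from compound 1 to compound 4 cannot be read, so no order among these three compounds can be stated.

As far as these compounds go, how far the true numbers of compound 1, compound 3 and compound 4 lie beyond the limit stays open, as does whether ring size, ring nitrogens or chain length matter most at this place. A cyclobutyl or cyclopentyl group on the same carbonyl carbon would show whether cyclopropyl stands alone in giving a true number or whether other small carbon rings do so too.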